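The source may report more compounds than this note shows. Statements on the series, on what has been measured and on what is new or still open speak of the compounds shown alone.

Compound 1 `Brc1cn2ccnc2c(-c2ccc3ncn(C4CCCCC4)c3c2)n1` gives 18.1% in a functional assay on NCI-H322M cells (Homo sapiens) for inhibition, read by sulforhodamine B assay, with a stated time of 48 h, tested at 10 uM; a lower number here means less inhibition, a higher number more inhibition at the concentration tested (going by the name of the read-out). Compound 2 `c1ccc(-c2cn3ccnc3c(-c3ccc4ncn(C5CCCCC5)c4c3)n2)cc1` gives 5.25%. Compound 3 `Fc1ccc(-c2cn3ccnc3c(-c3ccc4ncn(C5CCCCC5)c4c3)n2)cc1` gives 0.01%.

Compound 3 has the lowest of the three numbers, separated from compound 1 by a number 18.1 percentage points lower from compound 1 to compound 3 (beyond the scatter) but from compound 2 only by a number 5.2 percentage points lower from compound 2 to compound 3 (within the scatter), which is within the scatter. Compound 4 `FC(F)(F)c1cccc(-c2cn3ccnc3c(-c3ccc4ncn(C5CCCCC5)c4c3)n2)c1` differs from compound 3 by 3-(trifluoromethyl)phenyl in place of 4-fluorophenyl on an aromatic carbon. For the measured compounds named here, the steps that changed the aryl group are a number 12.9 percentage points lower from compound 1 to compound 2 (beyond the scatter) and a number 18.1 percentage points lower from compound 1 to compound 3 (beyond the scatter), both replacing bromo; the only aryl-to-aryl step, a number 5.2 percentage points lower from compound 2 to compound 3 (within the scatter), stayed within the scatter. Compound 4 is therefore expected to stay close to compound 3, and the step of a number 4 percentage points higher from compound 3 to compound 4 (within the scatter) is expected not to exceed the scatter. Compound 4 is estimated at 4%, between -6% and 16%.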

Compound 4, a percentage reported as inhibition, at one concentration (the size of the read-out at that concentration, not a potency): 5.83%
Estimate against measurement, compound 4: 1.8 percentage points below; low and high end bracket the measured number.
By their numbers in this assay, from the lowest: compounds 3, 2 and 4 (each within the scatter of the next); then compound 1.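

Exchanging the 4-fluorophenyl at this position for 3-(trifluoromethyl)phenyl gives a number 5.8 percentage points higher from compound 3 to compound 4 (within the scatter) in this assay, and adding trifluoromethyl to the phenyl gives a number 0.6 percentage points higher from compound 2 to compound 4 (within the scatter) so neither this new aryl group nor its added substituent separates compound 4 from the other two aryl compounds. Replacing bromo with this third aryl group again gives a step beyond the scatter, a number 12.3 percentage points lower from compound 1 to compound 4 (beyond the scatter) as the two earlier aryl groups did.

On these data alone, whether a group of another kind at this position, such as an amine or a carboxylic acid, would give a number nearer that of compound 1 or beyond it stays open. Nothing available accounts for these numbers.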